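This account rests on a few compounds, and the source may have more. Where it says the series, first, only, none or still open, it means among the compounds named here.

Measured compounds, with the number each gave in an assay on CHO cells for antagonist activity at transient receptor potential cation channel subfamily V member 1 (Homo sapiens), read by scintillation counting, with a stated time of 5 min; on this read-out lower numbers stand for stronger inhibition and higher numbers for weaker inhibition:

Compound 1 `CC(C(=O)NCc1ccc(C(F)(F)F)nc1N(C(C)C)S(=O)(=O)c1ccccc1)c1ccc(NS(C)(=O)=O)c(F)c1`: 27.6 nM
Compound 2 `CC(C(=O)NCc1ccc(C(F)(F)F)nc1N(Cc1ccccc1)S(C)(=O)=O)c1ccc(NS(C)(=O)=O)c(F)c1`: 25 nM
Compound 3 `CC(C(=O)NCc1ccc(C(F)(F)F)nc1N(Cc1ccccc1)S(=O)(=O)c1ccc(F)cc1)c1ccc(NS(C)(=O)=O)c(F)c1`: 3.87 nM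

All three share one core and differ only in the two groups on the sulfonylated nitrogen. In this assay compound 3 gives the lowest number of the three; the nearest is compound 2, and the step of a 6.5-fold lower number from compound 2 to compound 3 (0.81 log units; beyond the scatter) is beyond the scatter, as is the gap to compound 1, so compound 3 is the most potent compound measured here. Among the compounds with values here, no step between compounds 1 and 2 is worked out; their values show what they show.

Compound 4 `Cc1ccc(CN(c2nc(C(F)(F)F)ccc2CNC(=O)C(C)c2ccc(NS(C)(=O)=O)c(F)c2)S(=O)(=O)c2ccc(F)cc2)cc1` is the next compound. It differs from compound 3 in one place: methyl in place of hydrogen on an aromatic carbon, sitting on an aromatic carbon of a six-membered aromatic ring of carbon only, para to a large group; read one bond further out, the benzyl becomes a 4-methylbenzyl.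

Within the data shown here, none of the measured steps touches this position. Among the measured compounds shown here, the only worked-out step, a 6.5-fold lower number from compound 2 to compound 3 (0.81 log units; beyond the scatter), concerns the other group on the same nitrogen, and no pair differing by a methyl on an aromatic ring has been measured. The one-carbon change therefore gives no basis to expect a step in this assay beyond the scatter in either direction. The expectation is that compound 4 stays close to compound 3, with a step of a 1.0-fold higher number from compound 3 to compound 4 (0.01 log units; within the scatter). The estimate for compound 4 is 4 nM, within a range of 1.5 nM to 12 nM.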

Compound 4, inhibition constant: 7.08 nM
For compound 4 the middle estimate is 1.8-fold (0.25 log units) below the measured one; low and high end bracket the measured number.
By their numbers in this assay, from the lowest: compounds 3 and 4 (each within the scatter of the next); then compounds 2 and 1 (each within the scatter of the next).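

In this assay, turning the benzyl into a 4-methylbenzyl gives a 1.8-fold higher number from compound 3 to compound 4 (0.26 log units; within the scatter), so the two numbers cannot be told apart. Within the data shown here, this is the first measured change at this position, an aromatic carbon of a six-membered aromatic ring of carbon only, para to a large group, since the earlier step concerned the other group on the same nitrogen; it shows that a methyl can take the place of hydrogen here with no step beyond the usual scatter. Nothing available accounts for this outcome.

Going by these compounds, a single methyl is only one small probe of this position, so it remains open whether a longer chain such as propyl, or a more different group such as an amine or a carboxylic acid, on the same carbon would also stay within the scatter or would move the number in either direction. On these data alone, it is also open whether methyl would give the same result on another carbon of this ring, or on a compound with a different group on the sulfonyl sulfur.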